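A few compounds are considered here, and "the series" means these few. Any claim that something is new, unique, unknown or untested is made for them only; others in the source may bear on it.

Measured in a functional assay on KB/VCR cells (Homo sapiens) for cytotoxicity, read by sulforhodamine B assay, with a stated time of 72 h, tested at 25 uM; on this read-out higher numbers stand for weaker inhibition and lower numbers for stronger inhibition:

- Compound 1 `CCCCC[C@H](O)CCCCCCCC(=O)O[C@H]1[C@H](O[C@H]2C(O)O[C@H](COC(C)=O)[C@@H](O)[C@@H]2O)O[C@@H](C)[C@@H](OC(=O)[C@H](C)[C@@H](C)O)[C@H]1O[C@@H]1O[C@@H](C)[C@H](O)[C@@H](O)[C@H]1O`: 420 nM
- Compound 2 `CCC[C@H](O)CCCCCCCCCC(=O)O[C@H]1[C@H](O[C@H]2C(O)O[C@H](CO)[C@@H](O)[C@@H]2O)O[C@@H](C)[C@@H](OC(=O)[C@H](C)[C@@H](C)O)[C@H]1O[C@@H]1O[C@@H](C)[C@H](O)[C@@H](O)[C@H]1O`: 540 nM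

Compound 1 stands level with compound 2, since their two values lie within the usual scatter of each other. Compound 3 `CCC[C@H](O)CCCCCCCCCCCC(=O)O[C@H]1[C@H](O[C@H]2C(O)O[C@H](COC(C)=O)[C@@H](O)[C@@H]2O)O[C@@H](C)[C@@H](OC(=O)[C@H](C)[C@@H](C)O)[C@H]1O[C@@H]1O[C@@H](C)[C@H](O)[C@@H](O)[C@H]1O` differs from compound 1 by 5-hydroxyoctyl in place of 1-hydroxyhexyl on a saturated chain carbon, seven bonds along the chain from a carbonyl carbon. For the measured compounds named here, no measured pair shows this change alone, so the expectation in this assay is no step beyond the scatter, in either direction. The expected step is a 1.2-fold higher number from compound 1 to compound 3 (0.08 log units; within the scatter). For compound 3 the estimate is 500 nM, with an expected range of 200 nM to 1500 nM.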

Compound 3, half-maximal inhibitory concentration: 360 nM
The estimate for compound 3 lay 1.4-fold (0.14 log units) above the measured number; low and high end bracket the measured number.
By their numbers in this assay, from the lowest: compounds 3, 1 and 2 (each within the scatter of the next).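

Swapping 1-hydroxyhexyl for 5-hydroxyoctyl on a saturated chain carbon, seven bonds along the chain from a carbonyl carbon, gives a 1.2-fold lower number from compound 1 to compound 3 (0.07 log units; within the scatter) in this assay. For the compounds shown here, this is the first single-place comparison in the set, and it shows that this larger chain, which keeps its hydroxyl group, leaves the read-out within the scatter. Nothing available explains this result. Going by these compounds, whether a much longer chain would do the same remains open. So does the effect of an amine or a carboxylic acid in place of the hydroxyl group.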